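A few compounds are considered here, and "the series" means these few. Any claim that something is new, unique, unknown or untested is made for them only; others in the source may bear on it.

Measured compounds:
- compound 1 `O=C1NCCN1c1ccc(S(=O)(=O)Nc2ccc3[nH]ccc3c2)cc1` gives 87 nM
- compound 2 `Cc1cccc(NS(=O)(=O)c2ccc(N3CCNC3=O)cc2)c1` gives 69 nM
- compound 3 `COc1ccc(NS(=O)(=O)c2ccc(N3CCNC3=O)cc2)cc1OC` gives 340 nM

These three compounds share one core and differ only in the aryl group carried by the sulfonamide nitrogen. In a functional assay on M21 cells (Homo sapiens) for antiproliferative activity, read by sulforhodamine B assay, with a stated time of 48 h (a lower number here means a stronger inhibitor, a higher number a weaker inhibitor), compound 2 has the lowest of the three numbers. Compound 1 comes nearest, and the gap between them lies within the scatter of repeated runs, so no order between compound 1 and compound 2 can be claimed. Compound 3 lies furthest, and its gap to compound 2 is beyond the scatter.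

The step considered here leads from compound 2 to compound 4 `COc1ccccc1NS(=O)(=O)c1ccc(N2CCNC2=O)cc1`, which has not yet been measured in this assay. The change is 2-methoxyphenyl in place of 3-methylphenyl on a sulfonamide nitrogen.

Among the measured compounds shown here, no step between two measured compounds matches this change, so no direct guide exists. For the measured compounds named here, the only measured compound with a methoxy-bearing aryl group is compound 3, and compound 3 gives 340 nM, a higher number than compound 2. On that basis compound 4 is expected to give a modestly higher number than compound 2, with the step of a 2.2-fold higher number from compound 2 to compound 4 (0.34 log units; beyond the scatter) estimated to be small and possibly within the scatter. Compound 4 is therefore estimated at 150 nM, with a range from 50 nM to 500 nM.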

Compound 4, half-maximal inhibitory concentration: 300 nM
Beside the measured number, compound 4's estimate is 2.0-fold (0.30 log units) below it; the range from low to high includes it.
By their numbers in this assay, from the lowest: compounds 2 and 1 (each within the scatter of the next); then compounds 4 and 3 (each within the scatter of the next).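

Placing 2-methoxyphenyl in place of 3-methylphenyl on a sulfonamide nitrogen gives, in this assay, a 4.3-fold higher number from compound 2 to compound 4 (0.64 log units; beyond the scatter) and this is the first single step at this position that can be read, showing that the aryl group here can move the number beyond the scatter. Compound 4 and compound 3 lie within the scatter of each other, so among these four compounds the two with a methoxy-bearing aryl group form the higher pair, while compound 1 and compound 2 form the lower pair, and no compound shown goes against this split. Nothing available here gives a measured reason for the step.

The compounds shown leave open whether the step follows from the methoxy group itself or from where it sits on the ring. An unsubstituted phenyl on the sulfonamide nitrogen would give a plain reference point, and an aryl group bearing an amine, a carboxylic acid or a longer alkoxy chain would show how far the split between the two pairs holds.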